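Cyclobutyl for methyl on the aryl ether of compound 3

A few compounds are considered here, and "the series" means these few. Any claim that something is new, unique, unknown or untested is made for them only; others in the source may bear on it.

Measured so far:
compound 1, `CCOc1ccc(-c2c(C#N)c(N)nc(SCc3ccn[nH]3)c2C#N)cc1`, 18%
compound 2, `N#Cc1c(N)nc(SCc2cccc(C(N)=O)c2)c(C#N)c1-c1ccc(OCC2CC2)cc1`, 1%
compound 3, `CCOc1ccc(-c2c(C#N)c(N)nc(SCC(N)=O)c2C#N)cc1`, 20%

In an assay on CHO cells for displacement of a labelled ligand from adenosine receptor A3 (Homo sapiens), read by scintillation counting, with a stated time of 120 min, tested at 1 uM (on this read-out higher numbers stand for more inhibition at the one concentration tested (going by the name of the read-out) and lower numbers for less inhibition), compound 3 gives the largest of the three numbers, but compound 1 lies within the scatter of it; only compound 2 lies beyond the scatter, lower. For the measured compounds named here, the one measured step, a number 2 percentage points higher from compound 1 to compound 3 (within the scatter), concerns the sulfur side chain and is within the scatter. Compound 4, `N#Cc1c(N)nc(SCC(N)=O)c(C#N)c1-c1ccc(OCC2CCC2)cc1`, differs from compound 3 by cyclobutyl in place of methyl on a saturated chain carbon bound to an oxygen on an aromatic ring. Going by the values given here, no measured step touches this position; compound 2 carries a different ether, yet also a different sulfur side chain, so its value shows nothing separable. Compound 4 is therefore expected to change by a number 3 percentage points lower from compound 3 to compound 4 (within the scatter), not beyond the scatter, with an estimate of 17%, between 2% and 35%.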

Compound 4, a percentage reported as inhibition, at one concentration (the size of the read-out at that concentration, not a potency): 1%
Beside the measured number, compound 4's estimate is 16 percentage points above it, outside the stated range (below it).
By their numbers in this assay, from the lowest: compounds 2 and 4 (each within the scatter of the next); then compounds 1 and 3 (each within the scatter of the next).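

With the carbamoyl side chain on sulfur held fixed, the aryl ether proves to matter in this assay: cyclobutyl in place of methyl gives a number 19 percentage points lower from compound 3 to compound 4 (beyond the scatter). This is the only step shown at this position, and it lies beyond the scatter, whereas the change on the sulfur side chain, a number 2 percentage points higher from compound 1 to compound 3 (within the scatter), does not. Nothing measured here bears on why the number falls. From the compounds shown here alone, whether an open butoxy chain would fall equally remains open, as does whether cyclobutylmethoxy would have the same effect on the 1H-pyrazol-5-yl side chain of compound 1.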